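This account rests on a few compounds, and the source may have more. Where it says the series, first, only, none or still open, it means among the compounds named here.

Measured so far in a functional assay on HCT-116 cells (Homo sapiens) for antiproliferative activity, with a stated time of 48 h (a lower number here means a stronger inhibitor, a higher number a weaker inhibitor), are three compounds:
- Compound 1 `CCN(CC)c1ccc(-c2cccc(OC)c2)nn1` gives > 25000 nM as a limit of the assay, not a number
- Compound 2 `CC(=O)c1ccc(-c2ccc(N3CCCC3)nn2)cc1` gives > 25000 nM as a limit of the assay, not a number
- Compound 3 `CCN(CC)c1ccc(-c2ccc(C(C)=O)cc2)nn1` gives 6000 nM as a true number

Going by the values given here, compound 3 therefore holds the only true number in this small set, and the rest of the picture is the assay limit (the limit of > 25000 nM in this assay, at which 2 of the 3 values shown sit).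

The next structure is compound 4 `CCN(CC)c1ccc(-c2ccc(C(=O)O)cc2)nn1` with the change hydroxy in place of methyl on a carbonyl carbon in which acetyl becomes carboxy, that is, hydroxy in place of methyl on a carbonyl carbon. Among the compounds with values here, the one measured step, an at least 4.1-fold lower number from compound 2 to compound 3 (0.61 log units; beyond the scatter) concerns the diethylamino group, not the acetyl. It shows what a single change can do here, but it gives no direct guide to this one.

Most of the set stands at the limit of the assay. With compound 3 at 6000 nM, a move in this assay toward a higher number, meaning a weaker inhibitor, is expected. The estimated step is a 2.5-fold higher number from compound 3 to compound 4 (0.40 log units; beyond the scatter) and a report of only a limit is quite possible. Compound 4 is expected near 15000 nM with an estimated range from 5000 nM to 30000 nM in all.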

Compound 4, half-maximal inhibitory concentration: > 25000 nM
Compound 4: only a limit was reported; the forecaster's own chance of this, stated with the estimate: 50%; at least 1.6-fold (0.22 log units) between middle value and limit.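

In this assay, going by these compounds alone, the change from acetyl to carboxy gives an at least 4.1-fold higher number from compound 3 to compound 4 (0.61 log units; beyond the scatter), which is the first measured change at this position, as the earlier step concerned the diethylamino group. Compound 4 gives > 25000 nM, which is a limit of the assay and not a number. The step therefore shows that, with diethylamino kept in place, carboxy does not match acetyl here, but its true size stays unknown, as another compound joins the group at the limit: the limit of > 25000 nM in this assay, at which 3 of the 4 values shown sit.

From the compounds shown here alone, whether an amide, a methyl ester or a primary alcohol in place of the acetyl would keep or improve on the activity of compound 3 remains open. Also open, going by these compounds, is how a longer chain such as dipropylamino in place of diethylamino would change that activity.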